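This account rests on a few compounds, and the source may have more. Where it says the series, first, only, none or still open, it means among the compounds named here.

In a functional assay on MCF7 cells (Homo sapiens) for cytotoxicity, read by MTT assay, with a stated time of 48 h (on this read-out lower numbers stand for stronger inhibition and higher numbers for weaker inhibition), compound 1, `Cc1ccc(S(=O)(=O)/N=C(/CCNC2=CC(=O)c3ccccc3C2=O)Nc2ccccc2[N+](=O)[O-])cc1`, gives 3090 nM. Compound 2, `Cc1ccc(S(=O)(=O)/N=C(/CCNC2=CC(=O)c3ccccc3C2=O)Nc2ccc(F)c(F)c2)cc1`, carries a 3,4-difluorophenyl on the amine nitrogen in place of the 2-nitrophenyl of compound 1, and in this assay compound 2 gives 9420 nM. Among the compounds with values here, the step of a 3.0-fold higher number from compound 1 to compound 2 (0.48 log units; beyond the scatter) leaves compound 2 with the higher of the two numbers so far, the weaker of the pair.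

Compound 3, `Cc1ccc(S(=O)(=O)/N=C(/CCNC2=CC(=O)c3ccccc3C2=O)NC2CCCCC2)cc1`, differs from compound 2 as follows: cyclohexyl in place of 3,4-difluorophenyl on an amine nitrogen. Within the data shown here, the single measured step, from compound 1 to compound 2, exchanged one aromatic ring for another aromatic ring on this same nitrogen and shifted the number modestly; no measured step exchanges an aromatic ring for a non-aromatic one, so it offers only loose guidance for the present change. The shift is therefore expected to be of similar or smaller size, in either direction, with no firm ground for choosing a direction, and the step of a 1.0-fold lower number from compound 2 to compound 3 (0.02 log units; within the scatter) is the expectation that follows. On this basis compound 3 is estimated to give about 9000 nM in this assay, within a range from 3000 nM to 27000 nM.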

Compound 3, half-maximal inhibitory concentration: 7580 nM
Compound 3: the middle estimate sits 1.2-fold (0.07 log units) above what was measured; low and high end bracket the measured number.
By their numbers in this assay, from the lowest: compound 1; then compounds 3 and 2 (each within the scatter of the next).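

In this assay, the step of a 1.2-fold lower number from compound 2 to compound 3 (0.09 log units; within the scatter) gives the first reading of a non-aromatic ring on this amine nitrogen: cyclohexyl and 3,4-difluorophenyl cannot be told apart here, so among these compounds the number does not depend on whether the six-membered carbon ring is aromatic. The step of a 2.5-fold higher number from compound 1 to compound 3 (0.39 log units; beyond the scatter) adds a second replacement for 2-nitrophenyl, and since both replacements lie beyond the scatter from compound 1, compound 1 is the strongest of the three, with only its 2-nitrophenyl group standing apart at this position. No measurement given here bears on why these numbers fall as they do.

The compounds shown leave open whether the lower number of compound 1 belongs to the nitro group or to the aromatic ring that carries it, a question that a plain phenyl on the same nitrogen would help to settle. They also leave open whether any ring is needed at this position, or how an open hexyl chain, or a cyclohexyl ring carrying an amine or a carboxylic acid, would compare.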